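This account rests on a few compounds, and the source may have more. Where it says the series, first, only, none or still open, it means among the compounds named here.

Series notes. Compound 3 `CC(C)[C@H](NC(=O)COc1cccc2ccccc12)C(=O)N[C@@H](CC(=O)O)C(=O)COc1cc(F)ccc1F` gives 19700 nM in a functional assay with Homo sapiens as the target (a higher number here means a weaker inhibitor, a lower number a stronger inhibitor), the highest of the three numbers, though within the scatter of both neighbours: compound 1 `CC(C)[C@H](NC(=O)COc1cccc2ccccc12)C(=O)N[C@@H](CC(=O)O)C(=O)COc1cccc(C(F)(F)F)c1` gives 16600 nM and compound 2 `CC(C)[C@H](NC(=O)COc1cccc2ccccc12)C(=O)N[C@@H](CC(=O)O)C(=O)COc1ccc(F)cc1` gives 14300 nM. Compound 4 `CC(C)[C@H](NC(=O)COc1cccc2ccccc12)C(=O)N[C@@H](CC(=O)O)C(=O)COc1c(Cl)cccc1Cl` differs from compound 3 by 2,6-dichlorophenyl in place of 2,5-difluorophenyl on an oxygen on a saturated carbon. The three measured steps all change the aryl group at this same place: a 1.2-fold lower number from compound 1 to compound 2 (0.06 log units; within the scatter), a 1.2-fold higher number from compound 1 to compound 3 (0.07 log units; within the scatter) and a 1.4-fold higher number from compound 2 to compound 3 (0.14 log units; within the scatter), none beyond the scatter. The change to compound 4 is of the same kind, so no step beyond the scatter is expected in this assay, in either direction; the estimate for compound 4 is 18000 nM, range 8000 nM to 40000 nM, an expected step of a 1.1-fold lower number from compound 3 to compound 4 (0.04 log units; within the scatter).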

Compound 4, half-maximal inhibitory concentration: 15300 nM
For compound 4 the middle estimate is 1.2-fold (0.07 log units) above the measured one; low and high end bracket the measured number.
By their numbers in this assay, from the lowest: compounds 2, 4, 1 and 3 (each within the scatter of the next).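

In this assay the 2,6-dichlorophenyl group on this oxygen reads the same as the three earlier aryl groups: the steps (a 1.3-fold lower number from compound 3 to compound 4 (0.11 log units; within the scatter)), (a 1.1-fold higher number from compound 2 to compound 4 (0.03 log units; within the scatter)) and (a 1.1-fold lower number from compound 1 to compound 4 (0.04 log units; within the scatter)) all lie within the scatter. Chlorine on the phenyl ring therefore joins fluorine and trifluoromethyl among the changes at this place that give no step beyond the scatter. No supporting data bear on why this place stays flat.

Still open, on these data alone, is whether an amine or a carboxylic acid on the phenyl ring, or a saturated chain in place of the ring, would give a step beyond the scatter.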